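A Methylsulfonyl Group on the Shared Core

A few compounds are considered here, and "the series" means these few. Any claim that something is new, unique, unknown or untested is made for them only; others in the source may bear on it.

Compound 1 `CC(=O)Nc1nc(-c2ccc(Cl)c(Cl)c2)cs1` gives < 1000 nM as a limit
Compound 2 `N#CCC(=O)Nc1nc(-c2ccc(Cl)c(Cl)c2)cs1` gives 57000 nM
Compound 3 `O=C(Nc1nc(-c2ccc(Cl)c(Cl)c2)cs1)c1cncs1` gives 2000 nM

In a physicochemical assay for solubility, measured as kinetic solubility, with a stated time of 1 h, at pH 7.4 (a lower number here means a less soluble compound, a higher number a more soluble compound), compound 3 holds the lower of the two actual numbers (2000 nM), and the other actual number belongs to compound 2 (57000 nM). Compound 1 reports only a limit (< 1000 nM).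

Compound 4 `CS(=O)(=O)Nc1nc(-c2ccc(Cl)c(Cl)c2)cs1` has not yet been measured. It carries methylsulfonyl in place of (1,3-thiazol-5-yl)carbonyl on a nitrogen on an aromatic ring. Going by the values given here, no measured step makes this exact change, so the closest guides are the steps that alter the group on that same nitrogen. One is large (a 29-fold lower number from compound 2 to compound 3 (1.45 log units; beyond the scatter)), and so is another (an at least 57-fold higher number from compound 1 to compound 2 (1.75 log units; beyond the scatter)). The third has a floor within the scatter (an at least 2.0-fold higher number from compound 1 to compound 3 (0.30 log units; that floor lies within the scatter)). Compound 2 therefore suggests that losing the ring can bring a large gain, while compound 1 goes against that pattern. A small rise is expected in this assay, with a wide margin in both directions. The expected step is a 2.5-fold higher number from compound 3 to compound 4 (0.40 log units; beyond the scatter) and it remains an estimate. Compound 4 is expected at 5000 nM and estimated to fall from 1000 nM to 30000 nM in most repeat measurements.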

Compound 4, solubility: 429000 nM
For compound 4 the middle estimate is 86-fold (1.93 log units) below the measured one; measured number outside the range, above it.
By their numbers in this assay, from the lowest: compound 3; then compound 2; then compound 4. At a limit, below all of these: compound 1.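

In this assay, methylsulfonyl on a nitrogen on an aromatic ring gives the highest number of the four compounds, with a 210-fold higher number from compound 3 to compound 4 (2.33 log units; beyond the scatter), and it also exceeds the cyanomethyl amide that had led so far, with a 7.5-fold higher number from compound 2 to compound 4 (0.88 log units; beyond the scatter). The earlier compounds shown here varied only the group on the far side of a carbonyl, whereas compound 4 shows that replacing the carbonyl-linked group with a methylsulfonyl at this position can carry the number well beyond anything those compounds reached. Removing the ring does not account for this on its own, as the acetyl of compound 1 has no ring either, yet the change to methylsulfonyl still gives an at least 420-fold higher number from compound 1 to compound 4 (2.63 log units; beyond the scatter), a figure that is only a floor resting on the limit reported for compound 1: the limit of < 1000 nM in this assay, at which 1 of the 4 values shown sits.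

The compounds shown do not separate what the sulfonyl link contributes from what its methyl contributes, and a longer chain, a phenyl ring or an amine on the sulfur would test this. They also give no cause for the size of these steps, and they leave open whether the same change would hold on a different core.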